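Undrawn Stereocentres at a Free Fatty Acid Receptor Agonist

This account rests on a few compounds, and the source may have more. Where it says the series, first, only, none or still open, it means among the compounds named here.

Of the compounds shown here, three have been measured in a functional assay on CHO cells for agonist activity at Free fatty acid receptor 1 (Mus musculus), read by FLIPR and calcium flux; a lower number here means that less compound is needed, a higher number that more compound is needed for the effect. Compound 2, `CC#C[C@@H](c1ccc(Oc2ccc(C(F)(F)F)cc2OC(F)F)cc1)[C@H]1OC(=O)NC1=O`, gives 136 nM in this assay. Compound 3, `CC#CC(CC(=O)O)c1ccc(OC2CCCc3nc(-c4ccc(C)cc4)sc32)cc1`, gives 100 nM in this assay. Of the two numbers reported, that of compound 2 is the higher one, yet its gap to compound 3 lies within the scatter of repeated measurements, so the two are not separated by this assay. Going by the values given here, for compound 1, `CC#C[C@]1(c2ccc(Oc3ccc(C(F)(F)F)cc3Cl)cc2)C[C@H]1C(=O)O`, this assay returns no number but a limit, > 40000 nM; it is the only one of the three values that sits at a limit (the limit of > 40000 nM in this assay, at which 1 of the 3 values shown sits).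

Compound 4, `CC#CC(c1ccc(Oc2ccc(C(F)(F)F)cc2OC(F)F)cc1)C1OC(=O)NC1=O`, has not yet been measured. It is built of the same atoms and bonds as compound 2; the only difference is this: the two compounds have the same atoms and bonds; at least one stereo element is drawn with a configuration in one of them and without one in the other: 2 of 2 stereo elements differ; a stereocentre at a saturated chain carbon is drawn R in compound 2 and without a configuration in compound 4; a stereocentre at a saturated ring carbon is drawn R in compound 2 and without a configuration in compound 4. Among the compounds with values here, no measured pair in this set shows what such a change does. A compound drawn without configuration may be a mixture of stereoisomers, and the expectation is that its number in this assay will sit close to that of compound 2 or somewhat above it, with a step that may or may not exceed the scatter. Compound 4 is estimated at 250 nM, in a range from 110 nM to 900 nM. That estimate corresponds to an expected step of a 1.8-fold higher number from compound 2 to compound 4 (0.26 log units; within the scatter) in this assay.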

Compound 4, half-maximal effective concentration: 266 nM
Beside the measured number, compound 4's estimate is 1.1-fold (0.03 log units) below it; measured number inside the range.
By their numbers in this assay, from the lowest: compounds 3, 2 and 4 (each within the scatter of the next, the first and the last beyond it). At a limit, above all of these: compound 1.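

Compounds 2 and 4 form the first pair in this set that differ in one place, and what separates them is narrow: the fact that one of compounds 2 and 4 is drawn with a defined configuration and the other without, at the place where they differ

In this assay, the step is a 2.0-fold higher number from compound 2 to compound 4 (0.29 log units; within the scatter), so drawing both the saturated chain carbon and the saturated ring carbon as R, or leaving both without a configuration, does not separate the two compounds. Going by these compounds alone, this pair therefore gives no sign that the defined form and the form drawn without configuration differ in this assay, a question that none of the earlier compounds could address.

The compounds shown leave open what compound 4 contains and how a single stereoisomer drawn S at the saturated chain carbon, at the saturated ring carbon, or at both would read, so the contribution of each stereocentre cannot be separated from that of the other. Also open, as far as these compounds go, is what would follow on the core shared by compounds 2 and 4 if a nitrile or a methoxy group stood in place of the trifluoromethyl group.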